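This account rests on a few compounds, and the source may have more. Where it says the series, first, only, none or still open, it means among the compounds named here.

Two sulfonyl indoles have been measured. Compound 1 `COc1cccc2c1ccn2S(=O)(=O)c1ccccc1` gives 262 nM in an assay on isolated protein for displacement of a labelled ligand from 5-hydroxytryptamine receptor 6 (Homo sapiens), read by scintillation counting, with a stated time of 1 h (a higher number here means a weaker inhibitor, a lower number a stronger inhibitor), and compound 2 `O=S(=O)(c1ccccc1)n1cc(N2CCCCC2)c2ccccc21` gives 219 nM in this assay. Compound 2 stands at one end of these two numbers, yet the gap to compound 1 falls within the usual scatter, so the pair cannot be told apart. Compound 3 `O=S(=O)(c1ccccc1)n1cc(-c2ccccc2)c2ccccc21` carries phenyl in place of piperidin-1-yl on an aromatic carbon. Among the compounds with values here, no measured pair shows such a swap, so the estimate for compound 3 rests on compound 2 alone and is set as a small move beyond the scatter toward weaker binding, giving an expected step of a 2.1-fold higher number from compound 2 to compound 3 (0.31 log units; beyond the scatter). Compound 3 is expected at 450 nM, between 110 nM and 1800 nM.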

Compound 3, inhibition constant: 146 nM
Compound 3: the middle estimate sits 3.1-fold (0.49 log units) above what was measured; the range from low to high includes it.
By their numbers in this assay, from the lowest: compounds 3, 2 and 1 (each within the scatter of the next).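

In this assay, phenyl in place of piperidin-1-yl on this aromatic carbon gives a 1.5-fold lower number from compound 2 to compound 3 (0.18 log units; within the scatter) and so leaves the two compounds indistinguishable. This position therefore takes a six-membered aromatic ring of carbon only as well as a six-membered non-aromatic ring with a ring nitrogen, with no step beyond the scatter. Nothing available bears on why these two groups read alike.

The compounds shown leave open how a much smaller group, such as methyl, would read on this carbon. They also leave open whether a carboxylic acid or a primary amine there would give a step beyond the scatter.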